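The compounds below may be only part of what the source reports. "The series", "measured", "known", "first", "only" and "open" are said of these compounds alone.

In a functional assay on L1210 cells (Mus musculus) for inhibition, with a stated time of 48 h (on this read-out lower numbers stand for stronger inhibition and higher numbers for weaker inhibition), compound 1 (`CCCNCCCNCCCN`) gives > 100000 nM as its result, and this is a limit of the assay, not a number. In the same test compound 2 (`CCCNCCCCNCCCNCCC`) gives > 100000 nM as its result, again a limit and not a number. Compound 2 therefore has no exact position, and the limit of > 100000 nM in this assay, at which 2 of the 2 values shown sit, is all that the two results share. Going by the values given here, the one measured step, a step that the two limits leave unreadable from compound 1 to compound 2, offers no size to carry forward.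

Compound 3 (`CCCNCCCCNCCCCNCCC`) differs from compound 2 by a single change: (propylamino)methyl in place of propylamino on a saturated chain carbon, three bonds along the chain from an amine nitrogen. It carries (propylamino)methyl in place of propylamino on a saturated chain carbon, three bonds along the chain from an amine nitrogen. Since the earlier step has no readable size, neither a size nor a direction can be taken from it for this assay, and a result in the same high region, perhaps another limit, is expected. The expected change is an at least 1.2-fold lower number from compound 2 to compound 3 (0.09 log units; that floor lies within the scatter) on this estimate. For compound 3 the estimated value is 80000 nM, with an expected range from 10000 nM to 200000 nM overall.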

Compound 3, half-maximal inhibitory concentration: > 100000 nM
Compound 3: no number, only a limit; the forecaster's own chance of this, stated with the estimate: 60%; middle value at least 1.2-fold (0.09 log units) away from the limit.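

In this assay compound 3 gives > 100000 nM, a limit and not a number. No size or direction can be read for the step between compound 2 and compound 3, and the results shown share only this: the limit of > 100000 nM in this assay, at which 3 of the 3 values shown sit.

The compounds shown leave open what exact value any of them has in this assay.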